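Compound 3: swapping one basic amine for another on the shared core

A few compounds are considered here, and "the series" means these few. Any claim that something is new, unique, unknown or untested is made for them only; others in the source may bear on it.

Going by the values given here, in a functional assay on MCF7 cells (Homo sapiens) for antiproliferative activity, read by MTT assay, with a stated time of 72 h (a higher number here means a weaker inhibitor, a lower number a stronger inhibitor), compound 2 `CCN1CCN(c2cc(C)c3cc(NC(=O)c4ccc(Cl)c(Cl)c4)ccc3n2)CC1` gives 1380 nM, the lowest of the two numbers so far, though compound 1 `Cc1cc(NCCN(C)C)nc2ccc(NC(=O)c3ccc(Cl)c(Cl)c3)cc12` gives 2550 nM and a 1.8-fold lower number from compound 1 to compound 2 (0.27 log units; within the scatter) stays within the scatter. Compound 3 `Cc1cc(NCCN2CCCCC2)nc2ccc(NC(=O)c3ccc(Cl)c(Cl)c3)cc12` carries (2-(piperidin-1-yl)ethyl)amino in place of 4-ethylpiperazin-1-yl on an aromatic carbon. Among the compounds with values here, the only step that bears on this change is a 1.8-fold lower number from compound 1 to compound 2 (0.27 log units; within the scatter), which was within the scatter, and compound 3 resembles compound 1 in its side chain. No step beyond the scatter is therefore expected; the expected step is a 1.4-fold higher number from compound 2 to compound 3 (0.16 log units; within the scatter). Compound 3 is estimated at 2000 nM, with a range from 900 nM to 4500 nM.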

Compound 3, half-maximal inhibitory concentration in the MCF7 assay: 1190 nM
The estimate for compound 3 lay 1.7-fold (0.23 log units) above the measured number; measured number inside the range.
By their numbers in the MCF7 assay, from the lowest: compounds 3, 2 and 1 (each within the scatter of the next, the first and the last beyond it).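

Going by these compounds alone, in the MCF7 assay, the change at this position leaves a 1.2-fold lower number from compound 2 to compound 3 (0.06 log units; within the scatter), while piperidin-1-yl in place of dimethylamino on the chain gives a 2.1-fold lower number from compound 1 to compound 3 (0.33 log units; beyond the scatter), the only step in that assay beyond the scatter. In a physicochemical assay for solubility (a lower number here means a less soluble compound, a higher number a more soluble compound), compound 2 gives 11.3 ug/mL and compound 3 gives 70.8 ug/mL. The same change on the aromatic carbon therefore separates the two compounds in solubility but not in antiproliferative activity: the measured solubility of compound 2, 11.3 ug/mL, and of compound 3, 70.8 ug/mL, a 6.3-fold higher number (0.80 log units; beyond the scatter)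

On these data alone, the ring, the chain and the hydrogen-bond donor all change together in this one step, so their shares in the solubility gap remain open. A morpholin-4-yl group on the same ethylamino chain, or a longer chain carrying piperidin-1-yl, would begin to separate them.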